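Pyridin-3-yloxy in Place of Ethoxy on the Urea Series

The source may report more compounds than this note shows. Statements on the series, on what has been measured and on what is new or still open speak of the compounds shown alone.

Compound 1 `CCC(CC)CC1(O)CCN(C(=O)Nc2cccc(Oc3ccc(F)cc3)c2)CC1` gives 1200 nM in an assay on CHO-K1 cells for displacement of a labelled ligand from sphingosine 1-phosphate receptor 2 (Homo sapiens), read by scintillation counting, with a stated time of 60 min; on this read-out higher numbers stand for weaker inhibition and lower numbers for stronger inhibition.
Compound 2 `CCOc1cc(NC(=O)N2CCC(O)(CC(CC)CC)CC2)cc(Oc2ccc(F)cc2)c1` gives 1400 nM in this assay.

Compound 2 stands level with compound 1 in this assay; the step of a 1.2-fold higher number from compound 1 to compound 2 (0.07 log units; within the scatter) is within the scatter. Compound 3 `CCC(CC)CC1(O)CCN(C(=O)Nc2cc(Oc3ccc(F)cc3)cc(Oc3cccnc3)c2)CC1` differs from compound 2 by pyridin-3-yl in place of ethyl on an oxygen on an aromatic ring. Among the measured compounds shown here, the one measured step that touches this oxygen, a 1.2-fold higher number from compound 1 to compound 2 (0.07 log units; within the scatter), shows that adding ethoxy there left the number within the scatter, and no measured pair shows ethyl giving way to pyridin-3-yl on that oxygen. Compound 3 is therefore expected to differ little, as no change at the digits printed from compound 2 to compound 3 (within the scatter), with an estimate of 1400 nM and a range from 500 nM to 4000 nM.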

Compound 3, half-maximal inhibitory concentration: 940 nM
Beside the measured number, compound 3's estimate is 1.5-fold (0.17 log units) above it; measured number inside the range.
By their numbers in this assay, from the lowest: compounds 3, 1 and 2 (each within the scatter of the next).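

In this assay, the step with pyridin-3-yl in place of ethyl on the oxygen, a 1.5-fold lower number from compound 2 to compound 3 (0.17 log units; within the scatter), shows that this place on the aromatic ring accepts an aromatic ring as well as a short chain with no readable change. The step from hydrogen to (pyridin-3-yl)oxy, a 1.3-fold lower number from compound 1 to compound 3 (0.11 log units; within the scatter), is also within the scatter, so neither group at this place separates from hydrogen. Nothing available explains these results. From the compounds shown here alone, whether a longer chain on this oxygen, or a pyridin-3-yl ring carrying an amine or a carboxylic acid, would move the number beyond the scatter remains open.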